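The source may report more compounds than this note shows. Statements on the series, on what has been measured and on what is new or still open speak of the compounds shown alone.

The measured compounds, each tested in an assay on microsomes from intestine for inhibition of acyl-CoA:cholesterol acyltransferase (Oryctolagus cuniculus); on this read-out lower numbers stand for stronger inhibition and higher numbers for weaker inhibition:

compound 1, `Cc1cc(C)c(NC(=O)N(Cc2ccc(-c3ccccc3)nc2)C2CCCCCC2)c(C)c1`, gives 260 nM
compound 2, `Cc1cc(C)c(NC(=O)N(Cc2cccc(-c3cc[nH]n3)c2)C2CCCCC2)c(C)c1`, gives 39 nM
compound 3, `Cc1cc(C)c(NC(=O)N(Cc2ccc(-c3cccnc3)cc2)C2CCCCCC2)c(C)c1`, gives 130 nM

Among these three numbers compound 3 stands second highest. Its value and that of compound 1 lie within the usual scatter of each other, so no order between them can be read. Compound 2 sits beyond the scatter, with the lower number of the two.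

Compound 4, `Cc1cc(C)c(NC(=O)N(Cc2ccc(-c3cnn(C)c3)cc2)C2CCCCCC2)c(C)c1`, is the not yet measured member of the set. It differs from compound 3 in one place: 1-methyl-1H-pyrazol-4-yl in place of pyridin-3-yl on an aromatic carbon. Going by the values given here, no pair of measured compounds isolates this exchange, so its effect has to be judged without a direct precedent. Compound 2 also carries a five-membered aromatic ring with two hetero atoms, but on a different ring position, with a cyclohexyl group instead of cycloheptyl and without the methyl on the ring nitrogen, so it offers only a loose hint that such a ring is tolerated. The step from compound 3 to compound 4 is therefore expected to be small, a 1.2-fold lower number from compound 3 to compound 4 (0.07 log units; within the scatter), not clearly beyond the scatter, leaning if anything toward a lower number. Compound 4 is accordingly estimated at 110 nM, with a plausible range from 40 nM to 300 nM.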

Compound 4, half-maximal inhibitory concentration: 47 nM
Compound 4: middle estimate off by 2.3-fold (0.37 log units), on the high side, and the stated range covers the measured number.
By their numbers in this assay, from the lowest: compounds 2 and 4 (each within the scatter of the next); then compounds 3 and 1 (each within the scatter of the next).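

In this assay, going by these compounds alone, the exchange of pyridin-3-yl for 1-methyl-1H-pyrazol-4-yl on an aromatic carbon, para to a large group, gives a 2.8-fold lower number from compound 3 to compound 4 (0.44 log units; beyond the scatter) and is the first step here that isolates a single change. It shows that this position accepts a five-membered aromatic ring with 2 hetero atoms in place of a six-membered aromatic ring without loss of inhibition, and that the choice of ring there has a modest effect on the read-out beyond the scatter. No available evidence accounts for this step.

The compounds shown leave open how an ethyl or a longer chain on the ring nitrogen, or an amine or a carboxylic acid on the ring, would fare at this position. They also leave open whether the same exchange gives a similar step with cyclohexyl in place of cycloheptyl.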